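Benzyl for tert-butyl in the thiophene ester series

The source may report more compounds than this note shows. Statements on the series, on what has been measured and on what is new or still open speak of the compounds shown alone.

Three members of the series have been measured in an assay on membranes from HEK293 cells for displacement of a labelled ligand from adenosine receptor A2b (Homo sapiens), read by scintillation counting, with a stated time of 30 min, tested at 1 uM; a lower number here means less inhibition, a higher number more inhibition at the concentration tested (going by the name of the read-out). Compound 1 `CC1=C(C(=O)OC(C)(C)C)C(c2ccco2)NC(=S)N1` gives 9%. Compound 2 `CC1=C(C(=O)OCc2ccccc2)C(c2ccco2)NC(=S)N1` gives 41%, and compound 3 `CC1=C(C(=O)OC(C)(C)C)C(c2cccs2)NC(=S)N1` gives 26%. Compound 4 `CC1=C(C(=O)OCc2ccccc2)C(c2cccs2)NC(=S)N1` has not yet been measured in this assay.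

Two single changes connect the measured compounds. Compound 2 differs from compound 1 by benzyl in place of tert-butyl on an oxygen next to a carbonyl group, and this change gave a number 32 percentage points higher from compound 1 to compound 2 (beyond the scatter). The step from compound 1 to compound 3 gave a number 17 percentage points higher from compound 1 to compound 3 (beyond the scatter). Compound 3 thus stands second of the three in this assay, with compound 2 above it and compound 1 below it, both gaps beyond the scatter.

Compound 4 differs from compound 3 by benzyl in place of tert-butyl on an oxygen next to a carbonyl group. This is the same change as the one made from compound 1 to compound 2, at the same place, and it occurs twice among the compounds shown. The two cores on which it is made differ by thiophen-2-yl in place of furan-2-yl on a saturated ring carbon.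

The earlier occurrence of this change gave a number 32 percentage points higher from compound 1 to compound 2 (beyond the scatter), and the change from compound 3 to compound 4 is expected to give a step of similar direction but somewhat smaller size, a number 29 percentage points higher from compound 3 to compound 4 (beyond the scatter), since that expectation rests on a single earlier instance on a different core and compound 3 already starts higher than compound 1 did. Compound 4 is therefore estimated at 55% in this assay. The likely range for compound 4 is expected to run from 35% to 75%.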

Compound 4, a percentage reported as inhibition, at one concentration (the size of the read-out at that concentration, not a potency): 45%
Compound 4: middle estimate off by 10 percentage points, on the high side; low and high end bracket the measured number.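

In this assay, benzyl in place of tert-butyl on an oxygen next to a carbonyl group carries over to the core of compound 3 in the same direction, giving a number 19 percentage points higher from compound 3 to compound 4 (beyond the scatter), and the two occurrences cannot be told apart: the same change on two cores in this assay, a number 32 percentage points higher (beyond the scatter) from compound 1 to compound 2 and a number 19 percentage points higher (beyond the scatter) from compound 3 to compound 4, 13 percentage points apart, within the scatter of two such steps. Thiophen-2-yl in place of furan-2-yl on a saturated ring carbon, which raised the number on the tert-butyl ester, gives a number 4 percentage points higher from compound 2 to compound 4 (within the scatter) on the benzyl ester, yet this pair of steps also cannot be separated: the same change on two cores in this assay, a number 17 percentage points higher (beyond the scatter) from compound 1 to compound 3 and a number 4 percentage points higher (within the scatter) from compound 2 to compound 4, 13 percentage points apart, within the scatter of two such steps. The four compounds therefore support carrying the benzyl change between these two cores, with a rise beyond the scatter both times, but they do not show that the step has a fixed size, that it would hold on any other core, or that the two changes add up or interfere with each other.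

The compounds shown leave open whether a longer chain on the ester oxygen, or an amide or a carboxylic acid in place of the ester, would keep the inhibition seen with benzyl. They also leave open how a phenyl group on the saturated ring carbon, or a carbonyl in place of the thiocarbonyl, would read in this assay, and what potency lies behind these single-concentration percentages.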